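This account rests on a few compounds, and the source may have more. Where it says the series, first, only, none or still open, it means among the compounds named here.

Measured compounds:
compound 1 `N[C@@H](COP(=O)(O)OCCCOC(=O)CCc1ccccc1OCCCCOc1ccccc1)C(=O)O` in an assay on cells for activation of probable G-protein coupled receptor 34 (Mus musculus), with a stated time of 1 h (a higher number here means a larger maximal response, a lower number a smaller maximal response), gives 0.033
compound 2 `N[C@@H](COP(=O)(O)OCCCOC(=O)CCc1ccccc1OCc1cccc(Oc2ccccc2)c1)C(=O)O` in this assay gives 0.48
compound 3 `N[C@@H](COP(=O)(O)OCCCOC(=O)CCc1ccccc1OCc1cccc(Cc2ccccc2)c1)C(=O)O` in this assay gives 0.077

Compound 2 stands highest of the three numbers in this assay; its nearest neighbour is compound 3 and its furthest compound 1, and both gaps are beyond the scatter.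

Compound 4 `Cc1cccc(Oc2cccc(COc3ccccc3CCC(=O)OCCCOP(=O)(O)OC[C@H](N)C(=O)O)c2)c1` is the next compound in this line. It differs from compound 2 by methyl in place of hydrogen on an aromatic carbon.

Within the data shown here, only one measured step bears on the outer phenoxy part of compound 2: a number 0.40 lower from compound 2 to compound 3 (beyond the scatter), a large loss when the phenoxy itself is exchanged for benzyl. Among the measured compounds shown here, no measured pair shows a methyl added to an otherwise unchanged aromatic ring, so the size of the present step cannot be read from a close precedent. The phenoxy that distinguishes compound 2 from compound 3 is kept intact in compound 4, and the entering group is a single carbon without ring, donors or acceptors. The expected step is therefore small, within the scatter, in either direction: a number 0.030 lower from compound 2 to compound 4 (within the scatter).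

Compound 4 is estimated at 0.45 in this assay, within 0.25 to 0.7.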

Compound 4, intrinsic activity: the largest response reached, as a fraction of the reference agonist's: 0.29
Compound 4: the middle estimate sits 0.16 above what was measured; measured number inside the range.
By their numbers in this assay, from the lowest: compounds 1 and 3 (each within the scatter of the next); then compound 4; then compound 2.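

In this assay, the outer ring of the phenoxy group proves sensitive to a single added carbon: 3-methylphenoxy in place of phenoxy gives a number 0.19 lower from compound 2 to compound 4 (beyond the scatter) as a modest loss, so keeping the phenoxy group intact does not by itself preserve the full maximal response. Against the benzyl analogue the picture differs, with a number 0.21 higher from compound 3 to compound 4 (beyond the scatter) showing that 3-methylphenoxy still keeps a clear part of the response that benzyl loses. Nothing available explains either step.

Still open, as far as these compounds go, is whether this loss belongs to methyl alone or would also follow a chlorine atom or a methoxy group at the same place. Also open, from the compounds shown here alone, is whether methyl on another carbon of this ring would give a different maximal response.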